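Swapping the phenoxy substituent on a diaminoquinoxaline core

The source may hold more compounds than are shown below. What is called first, only, known or untested is meant among the compounds shown, and "the series" means these compounds.

Compound 1 `Nc1cc(N)c2nc(-c3ccccc3)c(Oc3ccc(Cl)c(Cl)c3)nc2c1` is the weaker of the two measured compounds in a functional assay on M14 cells (Homo sapiens) for inhibition, read by sulforhodamine B assay, with a stated time of 48 h; a lower number here means a stronger inhibitor of growth, a higher number a weaker inhibitor of growth: compound 1 gives 70800 nM, whereas compound 2 `COc1cc(CNc2nc3cc(N)cc(N)c3nc2-c2ccccc2)cc(OC)c1OC` gives 18200 nM, a gap that lies beyond the scatter of repeated runs. Since these two compounds differ at more than one place, nothing more can be drawn from their comparison than what the two values show.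

Compound 3 `Nc1cc(N)c2nc(-c3ccccc3)c(Oc3ccc(F)cc3)nc2c1` differs from compound 1 in a single place: 4-fluorophenyl in place of 3,4-dichlorophenyl on an oxygen on an aromatic ring. Going by the values given here, no pair of measured compounds shows this change, so its effect is not known from the data at hand. In the absence of such a precedent, the step is expected to stay small, with the number for compound 3 either within the scatter of compound 1 or modestly higher.

Compound 3 is therefore estimated at 90000 nM in this assay, with a range from 30000 nM to 250000 nM, corresponding to an expected step of a 1.3-fold higher number from compound 1 to compound 3 (0.10 log units; within the scatter).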

Compound 3, concentration for total growth inhibition: 44700 nM
The estimate for compound 3 lay 2.0-fold (0.30 log units) above the measured number; the range from low to high includes it.
By their numbers in this assay, from the lowest: compound 2; then compounds 3 and 1 (each within the scatter of the next).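

At this position, on an oxygen on an aromatic ring, replacing 3,4-dichlorophenyl with 4-fluorophenyl gives a 1.6-fold lower number from compound 1 to compound 3 (0.20 log units; within the scatter) in this assay. Going by these compounds alone, this is the first step read at this place, and it shows that this exchange of halogen-bearing phenyl groups leaves compound 1 and compound 3 within the scatter of each other, so the two groups cannot be told apart in this read-out. No available evidence offers an explanation for this result.

On these data alone, whether a 4-methoxyphenyl group, a pyridine ring or a short alkyl chain on the same oxygen would move the number beyond the scatter remains open. So does the question of whether 4-fluorophenyl and 3,4-dichlorophenyl would also stay this close on another cell line.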